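Fluoro in Place of Methyl: What Compound 4 May Show

The source may hold more compounds than are shown below. What is called first, only, known or untested is meant among the compounds shown, and "the series" means these compounds.

Of the compounds shown here, three of a shared core have been tested in a functional assay, with a stated time of 150 min, tested at 30 ug/mL; on this read-out higher numbers stand for a stronger effect at the one concentration tested and lower numbers for a weaker effect. Compound 1 `COC(=O)c1c(Nc2ccc(C)cc2)sc(C(=O)c2ccc(OC)cc2)c1C` is reported in this assay as "not active" (no number reported), with no number attached. Compound 2 `COC(=O)c1c(Nc2ccccc2)sc(C(=O)c2ccc(C)cc2)c1C` gives 9.35% in this assay. Compound 3 `COc1ccc(C(=O)c2sc(Nc3ccc(C)cc3)c(C(=O)O)c2C)cc1` is likewise reported in this assay as "not active" (no number reported), again without a number, so where compound 3 stands can only be said in words: it is one of two entries without a single value, and the only numbered entry, compound 2, sits low on the scale. No pairs among these three differ in one place alone, so no measured step is available to set a size of effect for any single change.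

Compound 4 `COc1ccc(C(=O)c2sc(Nc3ccc(F)cc3)c(C(=O)O)c2C)cc1` has not been measured. It differs from compound 3 by fluoro in place of methyl on an aromatic carbon. For the measured compounds named here, nothing among the measured compounds shows what this exchange does in this assay. Given that compound 3 is reported as "not active" (no number reported), compound 4 is expected to remain at the low end of this assay, and any step from compound 3 is expected to be none beyond the scatter. Compound 4 is therefore estimated at 5%, within a range from 0% to 15%, with a fair chance that it too is reported only as not active.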

Compound 4, a percentage reported as activity, at one concentration (the size of the read-out at that concentration, not a potency): 10.5%
The estimate for compound 4 lay 5.5 percentage points below the measured number; the range from low to high includes it.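

In this assay, for the compounds shown here, compound 3 is entered as "not active" (no number reported) and compound 4 gives 10.5% and with a number on one side only, no step between compound 3 and compound 4 can be read. The compounds shown leave open how large any effect of fluoro in place of methyl is on this read-out. Nothing shown here bears on the reason for this result.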